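A few compounds are considered here, and "the series" means these few. Any claim that something is new, unique, unknown or untested is made for them only; others in the source may bear on it.

Compound 1 `Nc1cccc2c(-c3cccc(NC(=O)c4ccc5c(c4)OCCO5)c3)ccnc12` carries an amino group on its core, and in a functional assay on MDA-MB-435 cells (Homo sapiens) for antiproliferative activity, read by sulforhodamine B assay, with a stated time of 48 h (a higher number here means a weaker inhibitor, a lower number a stronger inhibitor), compound 1 gives 30 nM. Compound 2 `CC(=O)Nc1cccc2c(-c3cccc(NC(=O)c4ccc5c(c4)OCCO5)c3)ccnc12` differs from compound 1 in a single spot: acetyl in place of hydrogen on a nitrogen on an aromatic ring. In this assay compound 2 gives 27 nM, so the change produces a 1.1-fold lower number from compound 1 to compound 2 (0.05 log units; within the scatter). Compound 3 `Nc1cccc2c(-c3cccc(NC(=O)Nc4cc(C(F)(F)F)cc(C(F)(F)F)c4)c3)ccnc12` keeps the amino group of compound 1 but carries a different attachment on the far side of the molecule; the difference between the two cores is not broken down here. In this assay compound 3 gives 1500 nM, the highest number of the three measured compounds, lying beyond the scatter from both compound 1 and compound 2.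

Compound 4 `CC(=O)Nc1cccc2c(-c3cccc(NC(=O)Nc4cc(C(F)(F)F)cc(C(F)(F)F)c4)c3)ccnc12` is to compound 3 what compound 2 is to compound 1: acetyl in place of hydrogen on a nitrogen on an aromatic ring. The surroundings of the changed nitrogen are described in identical words for both pairs, so this is the same change, made on the core of compound 3 instead of the core of compound 1. Because the earlier example of this change gave a 1.1-fold lower number from compound 1 to compound 2 (0.05 log units; within the scatter), the expected step in this assay is a 1.1-fold lower number from compound 3 to compound 4 (0.03 log units; within the scatter), which rests on that one prior measurement only. Compound 4 is therefore estimated to give 1400 nM in this assay, with a plausible range from 500 nM to 4000 nM.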

Compound 4, half-maximal inhibitory concentration: 15300 nM
For compound 4 the middle estimate is 11-fold (1.04 log units) below the measured one, outside the stated range (above it).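

On the second core, putting acetyl in place of hydrogen on the nitrogen on the aromatic ring gives a 10-fold higher number from compound 3 to compound 4 (1.01 log units; beyond the scatter) in this assay, so the amino to acetamido change that left the first core's number within the scatter is a large loss of activity here. The step seen on one core therefore did not predict the step on the other, and the effect of this change in the series depends on the core that carries it: the same change on two cores in this assay, a 1.1-fold lower number (0.05 log units; within the scatter) from compound 1 to compound 2 and a 10-fold higher number (1.01 log units; beyond the scatter) from compound 3 to compound 4, 11-fold (1.05 log units) apart, beyond the scatter of two such steps

This does not show which part of the far-side attachment makes the difference, since the two cores differ there by more than one atom, and a single pair on each core cannot say how the change would behave on a third core.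

The compounds shown leave open whether another group on this nitrogen, such as methyl or a longer acyl chain like propionyl, would follow the pair on the first core or the pair on the second. They also leave open whether the large step would persist on a far-side attachment with chlorine in place of each trifluoromethyl.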